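Quinoxalin-2-yl replacing benzimidazol-2-yl on a hedgehog inhibitor

The source may report more compounds than this note shows. Statements on the series, on what has been measured and on what is new or still open speak of the compounds shown alone.

Measured compounds:
compound 1, `Cc1nc(C(F)(F)F)ccc1C(=O)Nc1ccc(Cl)c(-c2nc3ccccc3[nH]2)c1`, 12 nM
compound 2, `Cc1nc(C(F)(F)F)ccc1C(=O)Nc1ccc(Cl)c(-c2nc3ccccc3n2C)c1`, 9 nM
compound 3, `Cc1nc(C(F)(F)F)ccc1C(=O)Nc1ccc(Cl)c(C(=O)Nc2ccccc2)c1`, 140 nM

In an assay on C3H 10T1/2 cells for inhibition of Sonic hedgehog protein (Mus musculus), read by a luciferase reporter (on this read-out lower numbers stand for stronger inhibition and higher numbers for weaker inhibition), compound 1 gives 12 nM, the second highest of the three numbers. Its nearest neighbour comes through the step of a 1.3-fold lower number from compound 1 to compound 2 (0.12 log units; within the scatter); its furthest through a 12-fold higher number from compound 1 to compound 3 (1.07 log units; beyond the scatter).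

Compound 4, `Cc1nc(C(F)(F)F)ccc1C(=O)Nc1ccc(Cl)c(-c2cnc3ccccc3n2)c1`, differs from compound 1 in one place: quinoxalin-2-yl in place of 1H-benzimidazol-2-yl on an aromatic carbon.

Two kinds of measured step bear on this. The step of a 1.3-fold lower number from compound 1 to compound 2 (0.12 log units; within the scatter) shows that methyl in place of hydrogen on the aromatic nitrogen, which removes the hydrogen-bond donor, leaves the number within the scatter. The steps of a 12-fold higher number from compound 1 to compound 3 (1.07 log units; beyond the scatter) and a 16-fold higher number from compound 2 to compound 3 (1.19 log units; beyond the scatter) show that phenylcarbamoyl in place of either benzimidazol-2-yl group is a large loss. Quinoxalin-2-yl likewise has no hydrogen-bond donor but remains an aromatic group of two rings joined to the core; the move from a five-membered to a six-membered aromatic ring with 2 hetero atoms has no measured precedent here. A small weakening at most is therefore expected, a 2.1-fold higher number from compound 1 to compound 4 (0.32 log units; beyond the scatter). Compound 4 is estimated at 25 nM, with a range from 8 nM to 80 nM.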

Compound 4, half-maximal inhibitory concentration in the Sonic hedgehog protein assay: 52 nM
Beside the measured number, compound 4's estimate is 2.1-fold (0.32 log units) below it; the measured number falls inside the stated range.
By their numbers in the Sonic hedgehog protein assay, from the lowest: compounds 2 and 1 (each within the scatter of the next); then compound 4; then compound 3.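

In the Sonic hedgehog protein assay the change to quinoxalin-2-yl costs measurable potency (a 4.3-fold higher number from compound 1 to compound 4 (0.64 log units; beyond the scatter); a 5.8-fold higher number from compound 2 to compound 4 (0.76 log units; beyond the scatter)), so loss of the ring hydrogen-bond donor alone does not account for the result, since compound 2 also lacks that hydrogen and stays within the scatter of compound 1. In the Sonic hedgehog protein assay this position still tolerates quinoxalin-2-yl better than phenylcarbamoyl (a 2.7-fold lower number from compound 3 to compound 4 (0.43 log units; beyond the scatter)), which places compound 4 in an intermediate rank. In a physicochemical assay for solubility, at pH 6.5 (a lower number here means a less soluble compound, a higher number a more soluble compound), compound 1 gives 0.3 ug/mL and compound 4 gives 0.1 ug/mL. In the physicochemical assay the same change also gives a lower number: the measured solubility of compound 1, 0.3 ug/mL, and of compound 4, 0.1 ug/mL, a 3.0-fold lower number (0.48 log units; beyond the scatter).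

The compounds shown cannot separate the effect of the six-membered ring with 2 hetero atoms from that of the added heavy atom. They also leave open how a five-membered benzoxazol-2-yl group, or an amine on the quinoxalin-2-yl group, would behave at this position.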